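Mirror-Image Cyclopropyl Amide and Its Expected Maximal Response

This account rests on a few compounds, and the source may have more. Where it says the series, first, only, none or still open, it means among the compounds named here.

Three amides built on one shared bicyclic core have been tested in an assay on CHO cells for agonist activity at Neuronal acetylcholine receptor; alpha3/alpha6/beta2/beta3 (Homo sapiens), read by FLIPR and calcium flux; on this read-out higher numbers stand for larger maximal responses and lower numbers for smaller maximal responses. Compound 1 `O=C(C1CCC1)N1CC2CC(C1)N2` gives 80%. Compound 2 `C[C@@H]1C[C@@H]1C(=O)N1CC2CC(C1)N2` gives 87%, and compound 3 `C[C@@H]1C[C@H]1C(=O)N1CC2CC(C1)N2` gives 110%, the highest of the three: the nearest step is a number 23 percentage points higher from compound 2 to compound 3 (beyond the scatter) and the furthest a number 30 percentage points higher from compound 1 to compound 3 (beyond the scatter). Compound 4 `C[C@H]1C[C@@H]1C(=O)N1CC2CC(C1)N2` keeps every atom and bond of compound 3 and differs only in drawn configuration: the two compounds have the same atoms and bonds; at least one stereo element is drawn with a configuration in one of them and without one in the other: 2 of 4 stereo elements differ; a stereocentre at a saturated ring carbon is drawn R in compound 3 and S in compound 4; a stereocentre at a saturated ring carbon is drawn R in compound 3 and S in compound 4. Among the measured compounds shown here, the one measured step that also turns a stereocentre, a number 23 percentage points higher from compound 2 to compound 3 (beyond the scatter), shows that such a change can move the response beyond the scatter, in either direction. Compound 4 is therefore expected to give roughly 90%, somewhere between 60% and 115%. The expected step is a number 20 percentage points lower from compound 3 to compound 4 (beyond the scatter).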

Compound 4, largest response reached (Emax), in percent of the reference or control that the assay uses: 64%
For compound 4 the middle estimate is 26 percentage points above the measured one, within the range that was stated.
By their numbers in this assay, from the lowest: compound 4; then compounds 1 and 2 (each within the scatter of the next); then compound 3.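

In this assay, configuration alone can now move the response in both directions from compound 2, since turning one stereocentre gives a number 23 percentage points lower from compound 2 to compound 4 (beyond the scatter), and turning both gives a number 46 percentage points lower from compound 3 to compound 4 (beyond the scatter). The 2-methylcyclopropyl group can also fall on either side of cyclobutyl, with a number 30 percentage points higher from compound 1 to compound 3 (beyond the scatter) but a number 16 percentage points lower from compound 1 to compound 4 (beyond the scatter). The gap between the two mirror-image amides can be traced only to how their stereocentres are drawn: the fact that one of compounds 3 and 4 is drawn with a defined configuration and the other without, at the place where they differ

The compounds shown leave open whether a 2-ethylcyclopropyl group on the carbonyl carbon would show the same dependence on configuration.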